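Swapping the carbamate cap for a cyclic amidine

The source may hold more compounds than are shown below. What is called first, only, known or untested is meant among the compounds shown, and "the series" means these compounds.

Compound 1 `CC(C)OC(=O)N1CCC(Oc2ncnc3c2CCN3c2ccc(S(C)(=O)=O)cc2F)CC1` is the reference. In a functional assay on CHO-K1 cells for agonist activity at Glucose-dependent insulinotropic receptor (Homo sapiens), read by a luciferase reporter, with a stated time of 5 h (on this read-out lower numbers stand for an effect already at smaller amounts and higher numbers for an effect only at larger amounts of compound), compound 1 gives 50.1 nM, the lowest of the three numbers seen so far. Compound 2 `CC(C)S(=O)(=O)N1CCC(Oc2ncnc3c2CCN3c2ccc(S(C)(=O)=O)cc2F)CC1` gives 1260 nM, and compound 3 `CC(C)c1noc(N2CCC(Oc3ncnc4c3CCN4c3ccc(S(C)(=O)=O)cc3F)CC2)n1` gives 79.4 nM. Compound 4 `CS(=O)(=O)c1ccc(N2CCc3c(OC4CCN(C5=NCCCN5)CC4)ncnc32)c(F)c1` carries a different group on the same nitrogen: a group of 6 heavy atoms (4 carbon, 2 nitrogen; one six-membered non-aromatic ring with 2 hetero atoms) in place of a group of 6 heavy atoms (4 carbon, 2 oxygen; no ring), on an amine nitrogen in a ring. Two earlier changes at this position show how much this cap matters: a 25-fold higher number from compound 1 to compound 2 (1.40 log units; beyond the scatter), whereas a 1.6-fold higher number from compound 1 to compound 3 (0.20 log units; within the scatter). The new group resembles neither earlier replacement, so the outcome is uncertain; the step is expected to fall between those two results, leaning toward a loss, and an 8.0-fold higher number from compound 1 to compound 4 (0.90 log units; beyond the scatter) is the estimated change. Compound 4 is therefore expected to give about 400 nM, within a range from 80 nM to 2500 nM.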

Compound 4, half-maximal effective concentration: 2000 nM
The estimate for compound 4 lay 5.0-fold (0.70 log units) below the measured number, and the stated range covers the measured number.
By their numbers in this assay, from the lowest: compounds 1 and 3 (each within the scatter of the next); then compounds 2 and 4 (each within the scatter of the next).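

A cap of the same size does not keep the effect: isopropoxycarbonyl and the new group both hold 6 heavy atoms, yet the change costs much (a 40-fold higher number from compound 1 to compound 4 (1.60 log units; beyond the scatter)). The loss is also large against the oxadiazole cap (a 25-fold higher number from compound 3 to compound 4 (1.40 log units; beyond the scatter)). Compound 4 instead sits level with the sulfonyl compound (a 1.6-fold higher number from compound 2 to compound 4 (0.20 log units; within the scatter)), so a second, quite different cap falls in that poor range. As far as these compounds go, whether the new hydrogen-bond donor matters stays open, and a methyl group on that ring nitrogen, or a pyrimidine ring as the cap, would test it. Nothing available here explains the loss.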